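Swapping the fluorophenyl arm for a hydroxy-phenylethyl arm

The compounds below may be only part of what the source reports. "The series", "measured", "known", "first", "only" and "open" are said of these compounds alone.

Measured so far:
compound 1 `Fc1ccc(CN2CCC(NCCSC(c3ccc(F)cc3)c3ccc(F)cc3)CC2)cc1`: 100%
compound 2 `[O-][S+](CCNC1CCN(Cc2ccc(F)cc2)CC1)C(c1ccc(F)cc1)c1ccc(F)cc1`: 100%

In an ADME assay on microsomes from liver (Rattus norvegicus) for metabolic stability, read by LC-MS, using NADPH, tested at 10 uM (on this read-out lower numbers stand for a less stable compound and higher numbers for a more stable compound), compound 1 gives 100%, and compound 2 gives 100%, so compound 1 stands level with compound 2 within the scatter. Compound 3 `OC(Cc1ccccc1)CN1CCC(NCCSC(c2ccc(F)cc2)c2ccc(F)cc2)CC1` is not yet measured. Its change from compound 1 is 1-hydroxy-2-phenylethyl in place of 4-fluorophenyl on a saturated chain carbon bound to an amine nitrogen in a ring. Because compound 1 already sits at 100% in this assay, no rise can show, so the expected step of a number 15 percentage points lower from compound 1 to compound 3 (beyond the scatter) is small and downward, or none beyond the scatter. Compound 3 is estimated at 85%, between 60% and 100%.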

Compound 3, percent of the compound remaining: 100%
Compound 3: the middle estimate sits 15 percentage points below what was measured; the measured number falls inside the stated range.
By their numbers in this assay, from the lowest: compounds 1, 2 and 3 (each within the scatter of the next).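

In this assay, 1-hydroxy-2-phenylethyl in place of 4-fluorophenyl, on a saturated chain carbon bound to an amine nitrogen in a ring, brings no change at the digits printed from compound 1 to compound 3 (within the scatter), with all values still at the top of the scale. So this arm can lose its fluorine and gain a hydroxy group without any drop showing, although a rise could not have shown here. No measurement shown here explains this result. Still open, going by these compounds, is whether an amine or a carboxylic acid on this arm would hold the value, and whether the longer chain without the hydroxy group would do so.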